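Swapping the Aryl Group on a Triazole Compound

This account rests on a few compounds, and the source may have more. Where it says the series, first, only, none or still open, it means among the compounds named here.

Measured so far:
compound 1, `O=C(NO)c1ccc(NCc2nc(-c3ccccc3Cl)nn2-c2ccccc2)cc1`, 75%
compound 2, `Nc1ccccc1NC(=O)c1ccc(NCc2nc(-c3ccccc3)nn2-c2ccccc2)cc1`, 5%

Within the data shown here, in an assay on Sf9 cells for inhibition of protein deacetylase HDAC6 (Homo sapiens), read by fluorescence, with a stated time of 40 min, tested at 100 nM (a higher number here means more inhibition at the concentration tested (going by the name of the read-out), a lower number less inhibition), compound 1 gives 75%, the higher of the two numbers known. Compound 2, which carries an aminoanilide in place of the hydroxamic acid and an unsubstituted phenyl instead of the 2-chlorophenyl, gives 5% in this assay, a gap well beyond the usual scatter. Since compound 2 differs from compound 1 in more than one place, the two values alone cannot say which change matters.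

Compound 3, `O=C(NO)c1ccc(NCc2nc(-c3cccc4cnccc34)nn2-c2ccccc2)cc1`, keeps the hydroxamic acid of compound 1 and changes only the aryl group on the triazole ring: isoquinolin-5-yl in place of 2-chlorophenyl on an aromatic carbon. With the hydroxamic acid retained, the step of a number 7 percentage points lower from compound 1 to compound 3 (within the scatter) is expected to stay within the scatter, perhaps a modest drop. Compound 3 is therefore estimated at 68% in this assay, in the range 45% to 88%.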

Compound 3, a percentage reported as inhibition, at one concentration (the size of the read-out at that concentration, not a potency): 40.2%
Estimate against measurement, compound 3: 27.8 percentage points above; the measured number lies below the stated range.
By their numbers in this assay, from the lowest: compound 2; then compound 3; then compound 1.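

The aryl group on this aromatic carbon of the five-membered ring clearly affects the result: in this assay, placing isoquinolin-5-yl in place of 2-chlorophenyl gives a number 34.8 percentage points lower from compound 1 to compound 3 (beyond the scatter), even with the hydroxamic acid kept. Compound 2 could not show this, since it differs from compound 1 in more than one place. The swap removes the chlorine, adds a second six-membered aromatic ring and brings in a ring nitrogen all at once, and nothing measured here explains the drop.

From the compounds shown here alone, what remains open is which of these changes matters: a naphthalen-1-yl group, with two fused rings of carbon only, would separate the second ring from the ring nitrogen. Also open, going by these compounds, is how an unsubstituted phenyl group would fare alongside the hydroxamic acid.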